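From 4-ethylpiperazin-1-yl to 4-acetylpiperazin-1-yl

The compounds below may be only part of what the source reports. "The series", "measured", "known", "first", "only" and "open" are said of these compounds alone.

In a functional assay on MGC-803 cells (Homo sapiens) for inhibition, read by CCK-8 assay, with a stated time of 48 h (on this read-out lower numbers stand for stronger inhibition and higher numbers for weaker inhibition), compound 1 (`COc1ccc(CN(C(=O)CSC(=S)N2CCc3ccccc32)c2cc(OC)c(OC)c(OC)c2)cc1`) gives 8410 nM. For compound 2 (`CCN1CCN(CC(=O)N(Cc2ccc(OC)cc2)c2cc(OC)c(OC)c(OC)c2)CC1`), > 20000 nM is a limit and not a number. For the measured compounds named here, the only measured step, an at least 2.3-fold higher number from compound 1 to compound 2 (0.37 log units; beyond the scatter), exchanges the whole group on the saturated chain carbon and bears on the next change only indirectly. Compound 3 (`COc1ccc(CN(C(=O)CN2CCN(C(C)=O)CC2)c2cc(OC)c(OC)c(OC)c2)cc1`) differs from compound 2 by acetyl in place of ethyl on an amine nitrogen in a ring. No step beyond the scatter is expected in this assay, and the estimated step is a step that the limit leaves unreadable from compound 2 to compound 3. Compound 3 is expected at 25000 nM, with an estimated range of 10000 nM to 60000 nM.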

Compound 3, half-maximal inhibitory concentration: 12800 nM
For compound 3 the middle estimate is 2.0-fold (0.29 log units) above the measured one; the range from low to high includes it.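

Acetyl in place of ethyl on the amine nitrogen in the ring gives an at least 1.5-fold lower number from compound 2 to compound 3 (0.19 log units; that floor lies within the scatter) in this assay, so a change at this position is not established, and its true size remains unknown. The value for compound 2 is a limit and not a number: the limit of > 20000 nM in this assay, at which 1 of the 3 values shown sits. The 4-acetylpiperazin-1-yl group and the larger group of compound 1 are not separated, with a 1.5-fold higher number from compound 1 to compound 3 (0.18 log units; within the scatter).

Open, going by these compounds, is how a benzoyl or a methanesulfonyl group on this amine nitrogen would read.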